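Shortening a hydroxymethyl arm on a piperidine ring

The source may report more compounds than this note shows. Statements on the series, on what has been measured and on what is new or still open speak of the compounds shown alone.

Measured compounds:
Compound 1 `COc1cc[nH]c1/C=C1\C(=O)Nc2ccc([N+](=O)[O-])cc21` — 7460 nM
Compound 2 `COc1cc[nH]c1/C=C1\C(=O)Nc2ccc([N+](=O)[O-])c(N3CCCC(CO)C3)c21` — 441 nM

In a functional assay on MDA-MB-435 cells (Homo sapiens) for antiproliferative activity, read by MTT assay, with a stated time of 5 days (on this read-out higher numbers stand for weaker inhibition and lower numbers for stronger inhibition), compound 2 gives 441 nM and stands as the lowest of the two numbers; its nearest neighbour is compound 1, reached by a 17-fold lower number from compound 1 to compound 2 (1.23 log units; beyond the scatter). Compound 3 `COc1cc[nH]c1/C=C1\C(=O)Nc2ccc([N+](=O)[O-])c(N3CCCC(O)C3)c21` differs from compound 2 by hydroxy in place of hydroxymethyl on a saturated ring carbon. Among the compounds with values here, no measured step bears directly on this change; the single step from compound 1 to compound 2 concerns adding the whole ring, not trimming its arm. Compound 3 is therefore expected to stay close to compound 2, with a 1.2-fold higher number from compound 2 to compound 3 (0.10 log units; within the scatter) not beyond the scatter. The estimate for compound 3 is 550 nM, between 200 nM and 1600 nM.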

Compound 3, half-maximal inhibitory concentration: 250 nM
For compound 3 the middle estimate is 2.2-fold (0.34 log units) above the measured one; measured number inside the range.
By their numbers in this assay, from the lowest: compounds 3 and 2 (each within the scatter of the next); then compound 1.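

In this assay, a hydroxy can replace the hydroxymethyl arm on the same saturated ring carbon without moving the number beyond the scatter (a 1.8-fold lower number from compound 2 to compound 3 (0.25 log units; within the scatter)). The large difference from the unsubstituted core also holds for 3-hydroxypiperidin-1-yl (a 30-fold lower number from compound 1 to compound 3 (1.47 log units; beyond the scatter)), so at this aromatic carbon it does not depend on the arm's extra carbon. Nothing available here explains these numbers. On these data alone, whether the ring needs an oxygen-bearing group at all remains open, as a plain piperidin-1-yl would show. How an amine or a carboxylic acid on that ring carbon would fare is also unknown.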